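From a Limit Toward a Fluorophenyl Amine

The compounds below may be only part of what the source reports. "The series", "measured", "known", "first", "only" and "open" are said of these compounds alone.

Compound 2 `Cc1cnc(Nc2ccc(C(C)C)cc2)nc1Nc1nc2ccccc2s1` reaches in a functional assay on HeLa cells (Homo sapiens) for antiproliferative activity, read by MTT assay, with a stated time of 48 h (a higher number here means a weaker inhibitor, a lower number a stronger inhibitor), only a limit, > 50000 nM, so no number is known for it; that point is the limit of > 50000 nM in this assay, at which 1 of the 3 values shown sits. Two relatives that carry a methylsulfonylphenyl group on the same nitrogen do give numbers. Compound 1 `CS(=O)(=O)c1ccc(Nc2ncc(F)c(Nc3nc4ccccc4s3)n2)cc1` gives 3170 nM in this assay, and compound 3 `CS(=O)(=O)c1ccc(Nc2nccc(Nc3nc4ccccc4s3)n2)cc1` gives 11300 nM, with a 3.6-fold higher number from compound 1 to compound 3 (0.55 log units; beyond the scatter).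

Compound 4 `Cc1cnc(Nc2cccc(F)c2)nc1Nc1nc2ccccc2s1` differs from compound 2 by a single exchange: 3-fluorophenyl in place of 4-isopropylphenyl on a nitrogen on an aromatic ring. Among the measured compounds shown here, the only measured step in this set, that from compound 1 to compound 3, concerns a fluoro on the shared core and not the aryl group on the nitrogen, so no measured step bears directly on this change. What can be said is that compound 2, with the isopropylphenyl group, sits at the limit, while compound 1 and compound 3, with a different aryl group at this position, land at measurable values. Compound 4 is therefore expected to give a number in this assay, estimated at 30000 nM, plausibly between 8000 nM and 100000 nM, though with a real chance of another limit. The estimated move is an at least 1.6-fold lower number from compound 2 to compound 4 (0.22 log units; that floor lies within the scatter), and it is stated with low confidence.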

Compound 4, half-maximal inhibitory concentration: 16300 nM
Beside the measured number, compound 4's estimate is 1.8-fold (0.26 log units) above it, and the stated range covers the measured number.
By their numbers in this assay, from the lowest: compound 1; then compounds 3 and 4 (each within the scatter of the next). At a limit, above all of these: compound 2.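

Exchanging 4-isopropylphenyl for 3-fluorophenyl on a nitrogen on an aromatic ring gives, in this assay, an at least 3.0-fold lower number from compound 2 to compound 4 (0.48 log units; beyond the scatter). Among the compounds shown here, this is the first measured step at this position, and it shows that the aryl group on this nitrogen can move the read-out on the core of compound 2, where compound 4 gives 16300 nM. The size of the step stays a floor and not a measured gap because compound 2 has only a limit and no number: the limit of > 50000 nM in this assay, at which 1 of the 4 values shown sits.

The exchange removes the isopropyl group and brings in a fluoro group at a different place on the phenyl ring in one move, going from 9 to 7 heavy atoms, so the compounds shown cannot tell which part of the change matters or whether either part would do the same alone. Also open, on these data alone, is how this position would respond to a plain phenyl group, or to a phenyl ring carrying an amine or a carboxylic acid, on the core of compound 4.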